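A few compounds are considered here, and "the series" means these few. Any claim that something is new, unique, unknown or untested is made for them only; others in the source may bear on it.

Measured compounds in a functional assay on HeLa cells (Homo sapiens) for antiproliferative activity, read by CCK-8 assay, with a stated time of 72 h, tested at 8 uM; a higher number here means a stronger effect of the compound at the concentration tested, a lower number a weaker effect:
compound 1, `Nc1ccccc1NC(=O)c1ccc(CSC(=S)N2CCN(Cc3ccccn3)CC2)cc1`: 61.4%
compound 2, `Nc1ccccc1NC(=O)c1ccc(CSC(=S)N2CCN(c3ccccc3)CC2)cc1`: 73.1%
compound 3, `CN(C(=S)SCc1ccc(C(=O)Nc2ccccc2N)cc1)c1cccnc1`: 70.5%

Compound 3 stands second highest of the three values. Its gap to compound 2 and its gap to compound 1 both lie within the scatter, so no order among the three is claimed.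

Compound 4 is `CN(Cc1cccnc1)C(=S)SCc1ccc(C(=O)Nc2ccccc2N)cc1`. It differs from compound 3 in one place: (pyridin-3-yl)methyl in place of pyridin-3-yl on an amide-type nitrogen.

Within the data shown here, the one measured step, a number 11.7 percentage points higher from compound 1 to compound 2 (beyond the scatter), runs in the opposite sense: there phenyl replaced (pyridin-2-yl)methyl on an amine nitrogen in a ring, and the number rose modestly, beyond the scatter. In the present step a methylene-linked ring takes the place of a directly attached ring, on a different nitrogen and with a different ring, so that step bears on it only loosely and in reverse. A modest decrease is therefore expected, though with one reference step a change within the scatter cannot be excluded.

For compound 4 the expected value in this assay is 62%, with an expected range of 48% to 76%. The expected step is a number 8.5 percentage points lower from compound 3 to compound 4 (within the scatter).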

Compound 4, a percentage reported as inhibition, at one concentration (the size of the read-out at that concentration, not a potency): 68.7%
The estimate for compound 4 lay 6.7 percentage points below the measured number, and the stated range covers the measured number.
By their numbers in this assay, from the lowest: compounds 1, 4, 3 and 2 (each within the scatter of the next, the first and the last beyond it).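

In this assay, (pyridin-3-yl)methyl in place of pyridin-3-yl on the amide-type nitrogen gives a number 1.8 percentage points lower from compound 3 to compound 4 (within the scatter) and so separates the two only within the scatter: on this nitrogen, the ring attached directly and the ring attached through a methyl link read alike at the concentration tested. This pair isolates that one difference, with the pyridin-3-yl ring kept, whereas the earlier step from compound 1 to compound 2 altered the ring and its link together on a nitrogen in a ring, so the loose reverse reading of that step finds no support here. Nothing available explains this result.

The compounds shown leave open whether a longer chain, such as 2-(pyridin-3-yl)ethyl, or a benzyl group on this nitrogen would keep the read-out. A single-concentration read-out also leaves any difference in potency between these two compounds open.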